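Swapping methyls for fluorines on the amide aryl group

A few compounds are considered here, and "the series" means these few. Any claim that something is new, unique, unknown or untested is made for them only; others in the source may bear on it.

Measured compounds:
compound 1 `O=C(Nc1cccc(-c2oc3cc(-c4ccc(F)cc4)ccc3c(=O)c2O)c1)c1ccc(F)cc1` gives 8590 nM
compound 2 `COc1ccc(C(=O)Nc2cccc(-c3oc4cc(-c5ccc(F)cc5)ccc4c(=O)c3O)c2)c(F)c1` gives 20000 nM
compound 3 `Cc1cc(C)cc(C(=O)Nc2cccc(-c3oc4cc(-c5ccc(F)cc5)ccc4c(=O)c3O)c2)c1` gives 20400 nM

Three compounds share one core and differ only in the aryl group attached to the amide carbonyl carbon. In a functional assay on MCF7 cells (Homo sapiens) for antiproliferative activity, read by CCK-8 assay, with a stated time of 72 h (a lower number here means a stronger inhibitor, a higher number a weaker inhibitor), compound 3 has the highest number of the three, although compound 2 sits within the scatter of it; compound 1 stands apart with a clearly lower number. Compound 4 `O=C(Nc1cccc(-c2oc3cc(-c4ccc(F)cc4)ccc3c(=O)c2O)c1)c1cc(F)cc(F)c1` is the next step: 3,5-difluorophenyl in place of 3,5-dimethylphenyl on a carbonyl carbon. The most telling measured step is a 2.4-fold higher number from compound 1 to compound 3 (0.38 log units; beyond the scatter), showing that a fluorine-bearing aryl gave the lower number. A return toward that is plausible, so a moderate drop is expected, a 1.9-fold lower number from compound 3 to compound 4 (0.27 log units; within the scatter). Compound 4 is therefore estimated at 11000 nM, with a likely range from 5000 nM to 28000 nM.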

Compound 4, half-maximal inhibitory concentration: 2490 nM
For compound 4 the middle estimate is 4.4-fold (0.65 log units) above the measured one; the whole stated range lies above it.
By their numbers in this assay, from the lowest: compound 4; then compound 1; then compounds 2 and 3 (each within the scatter of the next).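

Exchanging the methyls of the 3,5-dimethylphenyl group for fluorines keeps the heavy-atom count the same, yet in this assay it gives an 8.2-fold lower number from compound 3 to compound 4 (0.91 log units; beyond the scatter) as the clearest sign so far that this position is sensitive to the atoms on the aryl group. The 3,5-difluorophenyl group also improves on 4-fluorophenyl, with a 3.4-fold lower number from compound 1 to compound 4 (0.54 log units; beyond the scatter) beyond the scatter. A fluorine alone does not guarantee this, since moving away from 2-fluoro-4-methoxyphenyl gives an 8.0-fold lower number from compound 2 to compound 4 (0.90 log units; beyond the scatter) even though that group also carries one.

On these data alone, whether an amine, a carboxylic acid or a trifluoromethyl group on this aryl ring would lower the number further remains open. Nothing available here gives a reason for these differences.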